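The source may report more compounds than this note shows. Statements on the series, on what has been measured and on what is new or still open speak of the compounds shown alone.

Measured so far in a functional assay on MIA PaCa-2 cells (Homo sapiens) for inhibition, read by MTT assay, with a stated time of 3 days; a lower number here means a stronger inhibitor, a higher number a weaker inhibitor:
Compound 1 `CCOC(=O)[C@H]1CCN(S(=O)(=O)c2ccc(S(=O)(=O)N(CC)CC)cc2)C1` gives only a limit, > 10000 nM.
Compound 2 `CCN(CC)C(=O)c1ccc(S(=O)(=O)N2CCC[C@@H](C(=O)N3CCN(c4nc(C(C)C)no4)CC3)C2)cc1` gives 70 nM.
Compound 3 `CCOC(=O)[C@@H]1CCCN(S(=O)(=O)c2ccc(S(=O)(=O)N(CC)CC)cc2C)C1` gives 1200 nM.

Of the two numbers in hand, compound 2 has the lowest; compound 3, the nearest, lies beyond the scatter above it, and compound 1 adds a limit only. Compound 4 `CC(C)c1noc(N2CCN(C(=O)[C@@H]3CCCN(S(=O)(=O)c4ccc(S(=O)(=O)NC5CCC5)cc4)C3)CC2)n1` differs from compound 2 in one place: cyclobutylsulfamoyl in place of diethylcarbamoyl on an aromatic carbon. For the measured compounds named here, no measured pair isolates this change, so the expectation rests on compound 2 alone. A step of modest size toward a higher number in this assay is expected, possibly still within the scatter. Compound 4 is estimated at 150 nM, within 40 nM to 600 nM. The step this estimate implies is a 2.1-fold higher number from compound 2 to compound 4 (0.33 log units; beyond the scatter).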

Compound 4, half-maximal inhibitory concentration: 200 nM
Compound 4: middle estimate off by 1.3-fold (0.12 log units), on the low side, and the stated range covers the measured number.
By their numbers in this assay, from the lowest: compound 2; then compound 4; then compound 3. At a limit, above all of these: compound 1.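

In this assay, cyclobutylsulfamoyl in place of diethylcarbamoyl gives a 2.9-fold higher number from compound 2 to compound 4 (0.46 log units; beyond the scatter) at this aromatic carbon, para to a large group. For the compounds shown here, this is the first matched change, and it shows that this position accepts a sulfamoyl group carrying a four-membered ring at a modest cost in potency. Nothing in hand accounts for the size of this step.

Still open, going by these compounds, is whether the step follows the sulfamoyl link or the cyclobutyl ring, which cyclobutylcarbamoyl at this carbon would separate. On these data alone, how a carboxylic acid or a primary amine would read here also remains open.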